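The compounds below may be only part of what the source reports. "The series", "measured", "known", "first", "only" and "open" are said of these compounds alone.

The series shares the core of compound 1 `Cc1c(Cc2ccccc2)c(=O)oc2cc(OCC(O)CNc3nc4ccccc4[nH]3)ccc12`; in an ADME assay on A549 cells (Homo sapiens) for cytotoxicity, read by CellTiter-Glo (on this read-out higher numbers stand for lower toxicity in this test and lower numbers for higher toxicity in this test), compound 1 reports only the assay limit, > 100000 nM. Compound 2 `Cc1cc(F)ccc1Cc1c(C)c2ccc(OCC(O)CN3CCC(C(N)=O)CC3)cc2oc1=O` likewise gives only a limit, > 100000 nM, in this assay. On the numbers shown compound 2 stands where every value so far sits, as the limit of > 100000 nM in this assay, at which 2 of the 2 values shown sit, tells. Compound 3 `Cc1c(Cc2ccc(-c3ccccc3)cc2)c(=O)oc2cc(OCC(O)CN3CCC(C(N)=O)CC3)ccc12` is not yet measured and differs from compound 2 by 4-phenylphenyl in place of 4-fluoro-2-methylphenyl on a saturated chain carbon bound to an aromatic carbon. For the measured compounds named here, with no resolved step among the measured compounds, the expected step is at most a small move toward higher toxicity, an at least 1.2-fold lower number from compound 2 to compound 3 (0.09 log units; that floor lies within the scatter). For compound 3 the estimate in this assay is 80000 nM, within 30000 nM to 150000 nM.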

Compound 3, half-maximal cytotoxic concentration: > 100000 nM
Compound 3 was reported as a limit (the forecaster's own chance of this, stated with the estimate: 55%); at least 1.2-fold (0.09 log units) between middle value and limit.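

Compound 2 and compound 3 both report only a limit in this assay, so no step between them can be read: the limit of > 100000 nM in this assay, at which 3 of the 3 values shown sit.

The compounds shown leave open whether 4-phenylphenyl and 4-fluoro-2-methylphenyl differ at all in this assay.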